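This account rests on a few compounds, and the source may have more. Where it says the series, first, only, none or still open, it means among the compounds named here.

Compound 1, with the structure `CO/N=c1\[nH]cnc2c1[n+](C/C=C(\C)CC/C=C(\C)CC/C=C(\C)CCC=C(C)C)cn2CCC#N`, is the starting point of this small set. In a functional assay on cells (Homo sapiens) for cytotoxicity (a higher number here means a weaker inhibitor, a lower number a stronger inhibitor), compound 1 gives 3960 nM. Compound 2, drawn as `CC(C)=CCC/C(C)=C/CC/C(C)=C/CC/C(C)=C/C[n+]1cn(CCC#N)c2nc[nH]/c(=N\OCc3ccccc3)c21`, differs from it by phenyl in place of hydrogen on a saturated chain carbon bound to an oxygen; in this assay compound 2 gives 9460 nM, which is a 2.4-fold higher number from compound 1 to compound 2 (0.38 log units; beyond the scatter). Compound 3, with the structure `CO/N=c1\[nH]cnc2c1[n+](C/C=C(\C)CC/C=C(\C)CC/C=C(\C)CCC=C(C)C)cn2Cc1ccccc1`, is built on a different core, and the difference between the two cores is phenyl in place of cyanomethyl on a saturated chain carbon bound to an aromatic nitrogen. In this assay compound 3 gives 1040 nM, which is a 3.8-fold lower number from compound 1 to compound 3 (0.58 log units; beyond the scatter), and this is the lowest of the three measured numbers.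

Compound 4, drawn as `CO/N=c1\[nH]cnc2c1[n+](C/C=C(\C)CC/C=C(\C)CC/C=C(\C)CCC=C(C)C)cn2C(c1ccccc1)c1ccccc1`, has not yet been measured. It differs from compound 3 by phenyl in place of hydrogen on a saturated chain carbon bound to an aromatic carbon and an aromatic nitrogen. For the measured compounds named here, this is the same kind of change as the one from compound 1 to compound 2, but not the same: there the added phenyl sits on a saturated chain carbon bound to an oxygen, whereas here it sits on a saturated chain carbon bound to an aromatic carbon and an aromatic nitrogen, and the core of compound 3 differs from the core of compound 1 as already described. Going by the values given here, the only measured instance of this kind of change is a 2.4-fold higher number from compound 1 to compound 2 (0.38 log units; beyond the scatter). On that basis the step from compound 3 to compound 4 is expected to be a 2.2-fold higher number from compound 3 to compound 4 (0.34 log units; beyond the scatter), with wide uncertainty since the surroundings differ. For compound 4 the estimate in this assay is 2300 nM, expected to lie between 900 nM and 6000 nM.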

Compound 4, half-maximal inhibitory concentration: 2600 nM
Compound 4: the middle estimate sits 1.1-fold (0.05 log units) below what was measured; low and high end bracket the measured number.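

In this assay, phenyl in place of hydrogen on a saturated chain carbon bound to an aromatic carbon and an aromatic nitrogen gives a 2.5-fold higher number from compound 3 to compound 4 (0.40 log units; beyond the scatter), so the added ring moves the number upward, towards weaker inhibition. Set beside the earlier step, the size of the change carries over from one core to the other in this small series: the same change on two cores in this assay, a 2.4-fold higher number (0.38 log units; beyond the scatter) from compound 1 to compound 2 and a 2.5-fold higher number (0.40 log units; beyond the scatter) from compound 3 to compound 4, 1.0-fold (0.02 log units) apart, within the scatter of two such steps. For the compounds shown here, this agreement rests on only two pairs, and the phenyl sits on a different kind of carbon in each pair, so it shows a matching size in these two settings but neither explains that match nor promises the same step on a third core.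

The compounds shown have only hydrogen or phenyl at these two carbons, so it remains open whether a group such as an amine or a hydroxyl there would shift the number in the same direction or by a similar amount. Also open, as far as these compounds go, is how a shorter chain in place of the long unsaturated chain shared by compound 1, compound 2, compound 3 and compound 4 would affect these steps.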